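Amide variation on a shared core: cytotoxicity notes

The source may hold more compounds than are shown below. What is called first, only, known or untested is meant among the compounds shown, and "the series" means these compounds.

Compound 1 `COc1ccc(-c2cnc(NC(=O)C3CCCC3)n2C)cc1`, compound 2 `COc1ccc(-c2cnc(NC(=O)c3ccccc3)n2C)cc1` and compound 3 `CCCC(=O)Nc1ncc(-c2ccc(OC)cc2)n1C` share one core and differ only in the group on the carbonyl carbon. In a toxicity assay on THP-1 cells (Homo sapiens) for inhibition (on this read-out higher numbers stand for lower toxicity in this test and lower numbers for higher toxicity in this test), compound 1 reports a limit of > 100000 nM. In this assay compound 2 likewise reports a limit, > 100000 nM. Compound 3 also stands at a limit in this assay, > 100000 nM. The steps a step that the two limits leave unreadable from compound 1 to compound 2, a step that the two limits leave unreadable from compound 1 to compound 3 and a step that the two limits leave unreadable from compound 2 to compound 3 thus give no readable size; what the three share is the limit of > 100000 nM in this assay, at which 3 of the 3 values shown sit. Compound 4 `COc1ccc(-c2cnc(NC(=O)c3cnc[nH]3)n2C)cc1` differs from compound 3 by 1H-imidazol-5-yl in place of propyl on a carbonyl carbon. Within the data shown here, no measured step bears readably on this change, so no step beyond the scatter is expected in this assay, and the estimated step that the limit leaves unreadable from compound 3 to compound 4 remains at the limit. Compound 4 is expected at 150000 nM, between 50000 nM and 400000 nM.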

Compound 4, half-maximal cytotoxic concentration: > 100000 nM
Compound 4 was reported as a limit (the forecaster's own chance of this, stated with the estimate: 85%); the middle value is on the limit's open side.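

No step can be read for compound 4 against compound 1, compound 2 or compound 3, as all four stand at a limit: the limit of > 100000 nM in this assay, at which 4 of the 4 values shown sit.
As far as these compounds go, whether any group on the carbonyl carbon gives a readable value in this assay remains open.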